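Adding Fluoro to Compound 3

The source may report more compounds than this note shows. Statements on the series, on what has been measured and on what is new or still open speak of the compounds shown alone.

In a functional assay on MGC-803 cells (Homo sapiens) for antiproliferative activity, read by CellTiter-Glo, with a stated time of 72 h (on this read-out higher numbers stand for weaker inhibition and lower numbers for stronger inhibition), compound 1 `COc1ccccc1-c1cc(/C=C/c2ccc(C(=O)NO)cc2)ccn1` gives 6350 nM and compound 3 `Cc1ccc(-c2cc(/C=C/c3ccc(C(=O)NO)cc3)ccn2)cc1` gives 1910 nM, the lower of the two numbers. Compound 2 `O=C(NO)c1ccc(/C=C/c2ccnc(-c3ccc(F)cc3)c2)cc1` reaches only a limit, > 10000 nM. Compound 3 therefore stands lowest, with a 3.3-fold lower number from compound 1 to compound 3 (0.52 log units; beyond the scatter) and an at least 5.2-fold lower number from compound 2 to compound 3 (0.71 log units; beyond the scatter). Compound 4 `Cc1ccc(-c2cc(/C=C/c3ccc(C(=O)NO)cc3)ccn2)c(F)c1` differs by fluoro in place of hydrogen on an aromatic carbon. The closest measured change, an at least 5.2-fold lower number from compound 2 to compound 3 (0.71 log units; beyond the scatter), exchanges fluoro for methyl rather than adding fluoro while methyl stays, so it bears only loosely. A small rise within the scatter is therefore expected in this assay. The expected change is a 1.3-fold higher number from compound 3 to compound 4 (0.12 log units; within the scatter). For compound 4 the estimated value is 2500 nM, within an expected range of 900 nM to 7000 nM.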

Compound 4, half-maximal inhibitory concentration: 770 nM
Compound 4: the middle estimate sits 3.2-fold (0.51 log units) above what was measured; the whole stated range lies above it.
By their numbers in this assay, from the lowest: compound 4; then compound 3; then compound 1. At a limit, above all of these: compound 2.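

In this assay, fluoro ortho to a large group and meta to a methyl group is the first change shown that adds to the methyl group rather than replacing it, and the number falls: a 2.5-fold lower number from compound 3 to compound 4 (0.39 log units; beyond the scatter). The 2-fluoro-4-methylphenyl group also stands clear of the other two aryl groups, with an 8.2-fold lower number from compound 1 to compound 4 (0.92 log units; beyond the scatter) and an at least 12-fold lower number from compound 2 to compound 4 (1.11 log units; beyond the scatter). The second of these steps rests on a limit for compound 2, not a number: the limit of > 10000 nM in this assay, at which 1 of the 4 values shown sits.

The compounds shown give no cause for the fall. From the compounds shown here alone, whether chloro or an amine at this place would lower the number as fluoro does remains open.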